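A few compounds are considered here, and "the series" means these few. Any claim that something is new, unique, unknown or untested is made for them only; others in the source may bear on it.

Going by the values given here, compound 3 `O=c1[nH]cc(S(=O)(=O)Nc2ccc(-c3cn(-c4ccccc4F)nn3)cc2)c(=O)[nH]1` gives 8030 nM in a functional assay on OVCAR-3 cells (Homo sapiens) for antiproliferative activity, read by MTT assay, with a stated time of 24 h (on this read-out higher numbers stand for weaker inhibition and lower numbers for stronger inhibition), the highest of the three numbers measured so far. Compound 2 `O=c1[nH]cc(S(=O)(=O)Nc2ccccc2-c2cn(-c3ccccc3Cl)nn2)c(=O)[nH]1` gives 3170 nM in this assay, and compound 1 `Cc1cccc(-n2cc(-c3ccccc3NS(=O)(=O)c3c[nH]c(=O)[nH]c3=O)nn2)c1` gives 3150 nM, both beyond the scatter from compound 3.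

Compound 4 `O=c1[nH]cc(S(=O)(=O)Nc2ccc(-c3cn(-c4ccc(Cl)cc4)nn3)cc2)c(=O)[nH]1` differs from compound 3 by 4-chlorophenyl in place of 2-fluorophenyl on an aromatic nitrogen. Among the compounds with values here, the only measured step that changes the group on that aromatic nitrogen is a 1.0-fold higher number from compound 1 to compound 2 (0.00 log units; within the scatter), where one substituted phenyl replaced another and the number stayed put. That step, and nothing else, is what bears here, so no change beyond the scatter is expected. Compound 4 is therefore estimated at 8000 nM, between 3500 nM and 18000 nM. The expected step is a 1.0-fold lower number from compound 3 to compound 4 (0.00 log units; within the scatter).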

Compound 4, half-maximal inhibitory concentration: 2160 nM
Beside the measured number, compound 4's estimate is 3.7-fold (0.57 log units) above it; measured number below the stated range.
By their numbers in this assay, from the lowest: compounds 4, 1 and 2 (each within the scatter of the next); then compound 3.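

The group on this aromatic nitrogen can matter in this assay: 4-chlorophenyl in place of 2-fluorophenyl gives a 3.7-fold lower number from compound 3 to compound 4 (0.57 log units; beyond the scatter), a change beyond the scatter and towards stronger inhibition. The earlier swap of one substituted phenyl for another, a 1.0-fold higher number from compound 1 to compound 2 (0.00 log units; within the scatter), had shown no change, so such swaps are not always neutral. Nothing measured here explains the difference between these two steps. The step from compound 3 to compound 4 changes both the halogen and its place on the phenyl ring, and the two effects cannot be told apart. Going by these compounds, how a carbon chain ending in an amine would behave on this nitrogen also remains open.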